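The source may hold more compounds than are shown below. What is called first, only, known or untested is meant among the compounds shown, and "the series" means these compounds.

Working notes on the series. In a functional assay on A2780 cells (Homo sapiens) for inhibition, read by sulforhodamine B assay (on this read-out lower numbers stand for stronger inhibition of growth and higher numbers for weaker inhibition of growth), compound 1 (`c1ccc(-c2ccc(-c3ccc(-c4nc5ccccc5[nH]4)cc3)cc2)cc1`) gives 32100 nM, compound 2 (`COc1ccc(-c2ccc(-c3ccc(-c4nc5ccccc5[nH]4)cc3)cc2)cc1OC`) gives 21600 nM and compound 3 (`Oc1cccc2[nH]c(-c3ccc(-c4ccc(-c5ccccc5)cc4)cc3)nc12`) gives 41000 nM. The number for compound 3 lies within the scatter of both others, so the three compounds are not separated on this read-out.

The next compound is compound 4 (`Oc1cccc2[nH]c(-c3ccc(-c4ccc(-c5ccc(OC(F)(F)F)cc5)cc4)cc3)nc12`). It carries trifluoromethoxy in place of hydrogen on an aromatic carbon of compound 3, para to a large group: trifluoromethoxy in place of hydrogen on an aromatic carbon. Cut one bond further out, this reads phenyl to 4-(trifluoromethoxy)phenyl.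

For the measured compounds named here, two measured steps bear on this change. The closer one is a 1.5-fold lower number from compound 1 to compound 2 (0.17 log units; within the scatter), where 3,4-dimethoxyphenyl replaces the same phenyl. The other is a 1.3-fold higher number from compound 1 to compound 3 (0.11 log units; within the scatter), which adds the hydroxy that compound 3 and compound 4 share. Both stay within the scatter. Going by the values given here, no measured compound carries trifluoromethoxy, and none combines the hydroxy with a substituted phenyl, so this expectation is an extrapolation.

No step beyond the scatter is expected in this assay, and no direction is favoured. The expected step is a 1.4-fold lower number from compound 3 to compound 4 (0.14 log units; within the scatter). For compound 4 the estimated value is 30000 nM, with an expected range from 11000 nM to 70000 nM.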

Compound 4, concentration for 50% growth inhibition: 2900 nM
The estimate for compound 4 lay 10-fold (1.01 log units) above the measured number; the whole stated range lies above it.
By their numbers in this assay, from the lowest: compound 4; then compounds 2, 1 and 3 (each within the scatter of the next).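

In this assay, for the compounds shown here, the change from phenyl to 4-(trifluoromethoxy)phenyl gives a 14-fold lower number from compound 3 to compound 4 (1.15 log units; beyond the scatter) and is the first step to lie beyond the scatter. Going by these compounds alone, this shows that a substituent on this aromatic carbon, para to a large group, can move the number strongly, which the earlier compounds gave no sign of: the change from phenyl to 3,4-dimethoxyphenyl gave only a 1.5-fold lower number from compound 1 to compound 2 (0.17 log units; within the scatter) on a core without the hydroxy, and that step stays within the scatter.

Among the compounds shown, trifluoromethoxy occurs only together with the hydroxy, so it remains open whether a step of this size also holds on the core of compound 1, or whether the two groups depend on each other. From the compounds shown here alone, it is also open whether trifluoromethyl, an amine or a carboxylic acid in the same place would give a step of similar size and direction, or whether the step is particular to trifluoromethoxy. Nothing available here accounts for the size of this step.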